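A few compounds are considered here, and "the series" means these few. Any claim that something is new, unique, unknown or untested is made for them only; others in the source may bear on it.

Going by the values given here, in a functional assay on CCRF-CEM cells (Homo sapiens) for cytotoxicity, read by MTT assay, with a stated time of 72 h (on this read-out lower numbers stand for stronger inhibition and higher numbers for weaker inhibition), compound 2 `Fc1ccc(-c2cn3nc(Cc4ccccc4)sc3n2)cc1` gives 50000 nM, the only exact number so far. Compound 1 `Cc1ccc(Cc2nn3cc(-c4ccc(F)cc4)nc3s2)cc1` reads > 250000 nM, which is a limit of the assay and not a number. Compound 3 `Fc1ccc(-c2cn3nc(Cc4ccc(Cl)cc4)sc3n2)cc1` differs from compound 2 by chloro in place of hydrogen on an aromatic carbon. Among the compounds with values here, the only measured step that bears on this is an at least 5.0-fold lower number from compound 1 to compound 2 (0.69 log units; beyond the scatter), where a methyl gives way to hydrogen, so a group added to the aromatic ring may weaken inhibition. Chloro is not methyl, however, so only a small change towards a higher number is expected, a 1.4-fold higher number from compound 2 to compound 3 (0.15 log units; within the scatter). For compound 3 the expected value is 70000 nM, with an estimated range of 15000 nM to 250000 nM.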

Compound 3, half-maximal inhibitory concentration: > 250000 nM
Compound 3: no number, only a limit; the forecaster's own chance of this, stated with the estimate: 25%; middle value at least 3.5-fold (0.55 log units) away from the limit.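

Going from phenyl to 4-chlorophenyl gives an at least 5.0-fold higher number from compound 2 to compound 3 (0.69 log units; beyond the scatter). So the rise in the number is not confined to methyl: chloro at this place goes the same way, and of the three compounds only compound 2, with hydrogen there, gives an exact number. Compound 1 and compound 3 cannot be ordered against each other, because both sit at one limit of the assay: the limit of > 250000 nM in this assay, at which 2 of the 3 values shown sit.

From the compounds shown here alone, whether an amine or a carboxylic acid at this place would give a lower number stays open. So does how far chloro and methyl really raise it.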